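The source may report more compounds than this note shows. Statements on the series, on what has been measured and on what is new or still open speak of the compounds shown alone.

Measured so far:
- compound 1 `Cn1c(-c2ccc(NC(=O)CSc3nc4ccccc4o3)cc2)nc(-c2ccccc2)c1-c1ccccc1`: 42.3%
- compound 2 `Cn1c(-c2ccc(NC(=O)CSc3nc4ccccc4s3)cc2)nc(-c2ccccc2)c1-c1ccccc1`: 27%

For the measured compounds named here, in a functional assay on MCF7 cells (Homo sapiens) for cytotoxicity, read by MTT assay, with a stated time of 24 h, tested at 6.4 ug/mL (on this read-out lower numbers stand for a weaker effect and higher numbers for a stronger effect at the one concentration tested), compound 2 stands lowest of the two numbers; the only step in the set is a number 15.3 percentage points lower from compound 1 to compound 2 (beyond the scatter), a modest drop from a swap of the heteroaryl on the sulfur. Compound 3 `Cn1nnnc1SCC(=O)Nc1ccc(-c2nc(-c3ccccc3)c(-c3ccccc3)n2C)cc1` is not yet measured. Its change from compound 2 is 1-methyl-1H-tetrazol-5-yl in place of 1,3-benzothiazol-2-yl on a sulfur. Going by the values given here, no measured step covers this replacement; the one known step shows that exchanging the ring on the sulfur moves the read-out by a modest amount. For compound 3 a step of a number 2 percentage points lower from compound 2 to compound 3 (within the scatter) is expected, likely none beyond the scatter, giving an estimated 25% with a range from 10% to 45%.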

Compound 3, a percentage reported as activity, at one concentration (the size of the read-out at that concentration, not a potency): 55.9%
Estimate against measurement, compound 3: 30.9 percentage points below; measured number outside the range, above it.
By their numbers in this assay, from the lowest: compound 2; then compound 1; then compound 3.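

In this assay, 1-methyl-1H-tetrazol-5-yl in place of the two-ring groups on the sulfur gives a number 28.9 percentage points higher from compound 2 to compound 3 (beyond the scatter) and a number 13.6 percentage points higher from compound 1 to compound 3 (beyond the scatter). For the compounds shown here, a two-ring group on the sulfur is therefore not required for this read-out, and the only group of the three with a single ring stands highest. No measurement shown bears on the cause of this rise.

Open, going by these compounds, is whether the methyl group on the tetrazole contributes, which the unmethylated 1H-tetrazol-5-yl would test. Also open, on these data alone, is how a non-aromatic group on the sulfur, such as a simple amine-bearing chain, would read.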